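This account rests on a few compounds, and the source may have more. Where it says the series, first, only, none or still open, it means among the compounds named here.

Measured in a functional assay on DU-145 cells (Homo sapiens) for cytotoxicity, read by MTT assay, with a stated time of 48 h; on this read-out higher numbers stand for weaker inhibition and lower numbers for stronger inhibition:
compound 1, `CCOC(=O)c1c(-c2c(Cl)c3ccccc3oc2=O)nn(-c2ccccc2)c1C(=O)OCC`: 48000 nM
compound 2, `CCOC(=O)c1c(-c2c(Cl)c3ccccc3oc2=O)nn(-c2cccc(Cl)c2)c1C(=O)OCC`: 24000 nM
compound 3, `CCOC(=O)c1c(-c2c(Cl)c3ccccc3oc2=O)nn(-c2ccc(Br)cc2)c1C(=O)OCC`: 32000 nM

On these numbers compound 1 stands highest of the three, yet neither of the other two lies beyond the scatter from it: a 1.5-fold lower number from compound 1 to compound 3 (0.18 log units; within the scatter) and a 2.0-fold lower number from compound 1 to compound 2 (0.30 log units; within the scatter). Compound 2 and compound 3 also sit close together, a 1.3-fold higher number from compound 2 to compound 3 (0.12 log units; within the scatter).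

Compound 4, `CCOC(=O)c1c(-c2c(Cl)c3cc(C)ccc3oc2=O)nn(-c2ccccc2)c1C(=O)OCC`, has not been measured. It differs from compound 1 in one place: methyl in place of hydrogen on an aromatic carbon. The methyl sits on an aromatic carbon of a six-membered aromatic ring of carbon only, part of a fused or bridged system of two rings, meta to a fused ring and para to a fused ring. Among the measured compounds shown here, no measured step touches this ring. The two steps away from compound 1 each put a halogen onto an aromatic carbon elsewhere in the molecule, and both stayed within the scatter, so they bear on the present change only as a sign that single small additions have so far moved little. Compound 4 is therefore expected to show no step beyond the scatter, no change at the digits printed from compound 1 to compound 4 (within the scatter). The estimate for compound 4 is 48000 nM, in a range from 20000 nM to 110000 nM.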

Compound 4, half-maximal inhibitory concentration: 50000 nM
Estimate against measurement, compound 4: 1.0-fold (0.02 log units) below, within the range that was stated.
By their numbers in this assay, from the lowest: compounds 2, 3, 1 and 4 (each within the scatter of the next, the first and the last beyond it).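

In this assay, the step from hydrogen to methyl on the six-membered aromatic ring of carbon only, part of a fused or bridged system of two rings, gives a 1.0-fold higher number from compound 1 to compound 4 (0.02 log units; within the scatter). The other steps shown change only the ring on the aromatic nitrogen, so this is the sole reading at this place, and here a single methyl leaves the number within the scatter of the unsubstituted parent, compound 1. Nothing available accounts for this result or says what lies behind it.

The compounds shown leave open whether a group other than methyl at this place, such as an amine, a carboxylic acid or a longer alkyl chain, would move the number beyond the scatter. They also leave open whether methyl on the other carbons of this ring would behave in the same way.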